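This account rests on a few compounds, and the source may have more. Where it says the series, first, only, none or still open, it means among the compounds named here.

In a functional assay on A2780 cells (Homo sapiens) for inhibition, read by MTT assay, with a stated time of 72 h (a higher number here means a weaker inhibitor of growth, a lower number a stronger inhibitor of growth), compound 3 `COc1ccc(CNC(=O)/C(C#N)=C/c2ccc(Br)o2)cc1` gives 12000 nM. Within the data shown here, only one other number stands beside it: compound 2 `COc1ccc(CNC(=O)/C(C#N)=C/c2ccc(Cl)o2)cc1` gives 9000 nM, and the step of a 1.3-fold higher number from compound 2 to compound 3 (0.12 log units; within the scatter), bromo in place of chloro on an aromatic carbon, lies within the scatter, so the two cannot be ordered. Compound 1 `COc1ccc(CNC(=O)/C(C#N)=C/c2ccc[nH]2)cc1` gives only a limit of this assay, > 50000 nM. Compounds 2 and 3 both lie clearly away from that limit, as the steps of an at least 5.5-fold lower number from compound 1 to compound 2 (0.74 log units; beyond the scatter) and an at least 4.1-fold lower number from compound 1 to compound 3 (0.61 log units; beyond the scatter) show.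

Compound 4 `COc1ccc(CNC(=O)/C(C#N)=C/c2ccoc2)cc1` differs from compound 3 by furan-3-yl in place of 5-bromofuran-2-yl on a double-bonded chain carbon bound to a double-bonded chain carbon. The step of a 1.3-fold higher number from compound 2 to compound 3 (0.12 log units; within the scatter) bears on it only in showing that the two halogens on the furan are interchangeable within the scatter. The steps of an at least 5.5-fold lower number from compound 1 to compound 2 (0.74 log units; beyond the scatter) and an at least 4.1-fold lower number from compound 1 to compound 3 (0.61 log units; beyond the scatter) show that a 5-halofuran-2-yl group gives at least modestly lower numbers than 1H-pyrrol-2-yl, bounded by the limit (the limit of > 50000 nM in this assay, at which 1 of the 3 values shown sits). Among the measured compounds shown here, no measured step leads from a 5-bromofuran-2-yl group to a furan-3-yl group, so the effect of losing the bromine is untested. Compound 4 is expected to give a higher number, a modest step of a 2.5-fold higher number from compound 3 to compound 4 (0.40 log units; beyond the scatter). Compound 4 is estimated at 30000 nM in this assay, with a range from 10000 nM to 90000 nM.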

Compound 4, concentration for 50% growth inhibition: 6000 nM
Compound 4: the middle estimate sits 5.0-fold (0.70 log units) above what was measured; measured number below the stated range.
By their numbers in this assay, from the lowest: compounds 4, 2 and 3 (each within the scatter of the next). At a limit, above all of these: compound 1.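

In this assay, a halogen on the furan proves unnecessary for a reading in the range of compounds 2 and 3, since furan-3-yl cannot be told apart from either 5-halofuran-2-yl group: a 2.0-fold lower number from compound 3 to compound 4 (0.30 log units; within the scatter) and a 1.5-fold lower number from compound 2 to compound 4 (0.18 log units; within the scatter). The separation from 1H-pyrrol-2-yl at this place on a double-bonded chain carbon therefore also appears with a furan that carries no halogen, as an at least 8.3-fold lower number from compound 1 to compound 4 (0.92 log units; beyond the scatter) shows, so it is shared by all three furan compounds and is not tied to chloro or bromo. That last step is a bound and not an exact size, since compound 1 stands at a limit of the assay: the limit of > 50000 nM in this assay, at which 1 of the 4 values shown sits.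

Because compound 4 loses the halogen and also has furan-3-yl in place of a furan-2-yl group, the compounds shown leave open how a plain furan-2-yl group would read, which would separate those two changes. Also open, on these data alone, is whether a thiophen-3-yl group, a phenyl group or a 5-methylfuran-2-yl group at this place would read with the furans or nearer the limit of compound 1.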